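Swapping an oxolane for an oxazole on a fused core

A few compounds are considered here, and "the series" means these few. Any claim that something is new, unique, unknown or untested is made for them only; others in the source may bear on it.

Measured so far:
compound 1, `Cc1cc(C)c(CN2CCc3c(Cl)cc([C@@H](CO)[C@@H]4CCOC4)c(Cl)c3C2=O)c(=O)[nH]1` — 3 10^-6 cm/s
compound 2, `Cc1cc(C)c(CN2CCc3c(Cl)cc([C@@H](CO)[C@@H]4CCCO4)c(Cl)c3C2=O)c(=O)[nH]1` — 4.3 10^-6 cm/s

Two compounds have been run in an ADME assay on MDCK cells (Canis lupus familiaris) for permeability, read by LC-MS, with a stated time of 90 min, tested at 2 uM; on this read-out lower numbers stand for lower permeability and higher numbers for higher permeability. Compound 1 `Cc1cc(C)c(CN2CCc3c(Cl)cc([C@@H](CO)[C@@H]4CCOC4)c(Cl)c3C2=O)c(=O)[nH]1` gives 3 10^-6 cm/s; compound 2 `Cc1cc(C)c(CN2CCc3c(Cl)cc([C@@H](CO)[C@@H]4CCCO4)c(Cl)c3C2=O)c(=O)[nH]1` gives 4.3 10^-6 cm/s. Among the measured compounds shown here, on these two numbers compound 2 stands highest, but the only step between them, a 1.4-fold higher number from compound 1 to compound 2 (0.16 log units; within the scatter), lies within the scatter, so the two values are best read as the same.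

Compound 3 `Cc1cc(C)c(CN2CCc3c(Cl)cc(-c4c(C)noc4C)c(Cl)c3C2=O)c(=O)[nH]1` has not yet been measured in this assay. It differs from compound 2 as follows: a group of 7 heavy atoms (5 carbon, 1 nitrogen, 1 oxygen; one five-membered aromatic ring with 2 hetero atoms) in place of a group of 8 heavy atoms (6 carbon, 2 oxygen; one five-membered non-aromatic ring with 1 hetero atom), on an aromatic carbon. For the measured compounds named here, the one measured step, a 1.4-fold higher number from compound 1 to compound 2 (0.16 log units; within the scatter), moved an oxolane ring from one attachment point to another and left the hydroxymethyl-bearing carbon in place; it does not speak to the loss of the hydrogen-bond donor and of both stereocentres that separates compound 2 from compound 3. Going by the values given here, with no step of this kind on record, the expectation for compound 3 rests on the value of compound 2, 4.3 10^-6 cm/s, and is an upward step, a 2.3-fold higher number from compound 2 to compound 3 (0.37 log units; beyond the scatter), carried by a wide range. Compound 3 is therefore estimated at 10 10^-6 cm/s, between 4 10^-6 cm/s and 25 10^-6 cm/s.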

Compound 3, apparent permeability: 15.7 10^-6 cm/s
Compound 3: the middle estimate sits 1.6-fold (0.20 log units) below what was measured; the measured number falls inside the stated range.
By their numbers in this assay, from the lowest: compounds 1 and 2 (each within the scatter of the next); then compound 3.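

In this assay, among the compounds shown here, the aromatic carbon ortho to a chloro group proves sensitive to what it carries: placing 3,5-dimethyl-1,2-oxazol-4-yl there gives a 3.7-fold higher number from compound 2 to compound 3 (0.56 log units; beyond the scatter) and a 5.2-fold higher number from compound 1 to compound 3 (0.72 log units; beyond the scatter), both beyond the scatter, whereas the oxolane attachment change between the earlier compounds had not moved the number beyond it. This single change alters several things at once, with an aromatic ring replacing a non-aromatic one, the hydrogen-bond donor count going from 1 to 0, and the 2 defined stereocentres of the leaving group disappearing, so the step cannot be assigned to any one of them. No measurement at hand bears on the origin of this rise.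

On these data alone, it remains open whether the higher number follows the aromatic ring or the loss of the hydroxymethyl group, a question that an oxolane-bearing chain ending in a plain methyl, or a hydroxymethyl chain carrying the 3,5-dimethyl-1,2-oxazol-4-yl ring, would help to separate. Also open, as far as these compounds go, is how a phenyl ring, an unsubstituted 1,2-oxazole or an aminomethyl group would read at this position.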